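A few compounds are considered here, and "the series" means these few. Any claim that something is new, unique, unknown or untested is made for them only; others in the source may bear on it.

Measured in a functional assay on BV-2 cells (Mus musculus) for inhibition, read by Griess assay, with a stated time of 24 h; on this read-out higher numbers stand for weaker inhibition and lower numbers for stronger inhibition:
- Compound 1 `Oc1ccc(Br)cc1-c1ccn(Cc2ccccc2)n1`: > 200000 nM, a limit
- Compound 2 `C=CCn1ccc(-c2cc(Br)ccc2OC)n1`: > 200000 nM, a limit
- Compound 3 `COc1ccc(Br)cc1-c1ccn(-c2ccccc2)n1`: > 200000 nM, a limit

Compound 3 has no exact number to its name, only the limit of this assay, and it cannot be ranked against the other two. The whole picture so far is the limit of > 200000 nM in this assay, at which 3 of the 3 values shown sit.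

Compound 4 `COc1ccc(Br)cc1-c1ccn(Cc2ccccc2)n1` keeps the rest of compound 3 and changes one group: benzyl in place of phenyl on an aromatic nitrogen. In words, this is benzyl in place of phenyl on an aromatic nitrogen.

Within the data shown here, only one measured step concerns a group at this place, namely phenyl in place of allyl on an aromatic nitrogen. It is a step that the two limits leave unreadable from compound 2 to compound 3, so it offers no size to carry over to the new change. With compound 3 at > 200000 nM, a limit, and no readable step to guide the change, no shift beyond the scatter is expected in this assay, and another limit is the most likely report. The estimated step is a number no higher from compound 3 to compound 4 (the limit leaves the size open). For compound 4 the expected value is 200000 nM, with an estimated range from 100000 nM to 400000 nM.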

Compound 4, half-maximal inhibitory concentration: > 200000 nM
Compound 4: a limit, no number; the forecaster's own chance of this, stated with the estimate: 75%; the middle value sits exactly at the limit.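

In this assay compound 4 gives > 200000 nM, a limit and not a number. No step from compound 1, compound 2 or compound 3 to compound 4 can be read, since all four compounds share one result: the limit of > 200000 nM in this assay, at which 4 of the 4 values shown sit.

The compounds shown leave open how much any of these group changes shifts inhibition, and what on the shared core would give an exact value.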